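Glutamate-to-lysine swap on the cyclopropylamino-purine glycinamide series

The source may hold more compounds than are shown below. What is called first, only, known or untested is meant among the compounds shown, and "the series" means these compounds.

Of the compounds shown here, three measured so far. Compound 1 `O=C(OCc1ccccc1)[C@@H]1CCCN1C(=O)CN(c1nc(Cl)nc2[nH]cnc12)C1CC1` gives 31.1% in a functional assay on the whole organism (Tail, strain ICR) with Mus musculus as the target, in the tail flick test, with a stated time of 150 min, at a dose of 25 umol/kg by the oral route; on this read-out lower numbers stand for a weaker effect and higher numbers for a stronger effect at the one dose given. Compound 2 `O=C(CN(c1nc(Cl)nc2[nH]cnc12)C1CC1)N[C@@H](CCC(=O)OCc1ccccc1)C(=O)OCc1ccccc1` gives 44.5% in this assay. Compound 3 `O=C(O)CC[C@H](NC(=O)CN(c1nc(Cl)nc2[nH]cnc12)C1CC1)C(=O)O`, the free diacid, gives 29.5% in this assay; its number and that of compound 1 lie within the scatter of each other, while compound 2 stands beyond the scatter above compound 3. Compound 4 `NCCCC[C@H](NC(=O)CN(c1nc(Cl)nc2[nH]cnc12)C1CC1)C(=O)O` differs from compound 3 as follows: 2-aminoethyl in place of carboxy on a saturated chain carbon, three bonds along the chain from an amide-type nitrogen and a carbonyl carbon. Among the measured compounds shown here, no measured step of this kind exists in the set. The step from compound 3 to compound 4 is expected to be small, with no clear direction and not beyond the scatter, a number 3.5 percentage points higher from compound 3 to compound 4 (within the scatter). Compound 4 is therefore estimated at 33%, with a range from 18% to 50%.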

Compound 4, a percentage reported as activity, at one dose (the size of the read-out at that dose, not a potency): 11.6%
Estimate against measurement, compound 4: 21.4 percentage points above; measured number below the stated range.
By their numbers in this assay, from the lowest: compound 4; then compounds 3 and 1 (each within the scatter of the next); then compound 2.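

Among the compounds shown here, at this position, on a saturated chain carbon, three bonds along the chain from an amide-type nitrogen and a carbonyl carbon, the change is not neutral: in this assay 2-aminoethyl in place of carboxy gives a number 17.9 percentage points lower from compound 3 to compound 4 (beyond the scatter), the first single-place step. Nothing measured bears on why the number moves.

From the compounds shown here alone, whether the fall follows the arrival of the amine or the loss of the carboxylic acid stays open; a plain butyl chain at this place would separate the two.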